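A few compounds are considered here, and "the series" means these few. Any claim that something is new, unique, unknown or untested is made for them only; others in the source may bear on it.

Measured in a functional assay on BJAB cells (Homo sapiens) for antiproliferative activity, with a stated time of 4 days; on this read-out higher numbers stand for an effect only at larger amounts of compound and lower numbers for an effect already at smaller amounts:
compound 1 `Cc1nn(-c2nc(-c3ccc(Cl)c(Cl)c3)c(SC(C)C)s2)c(C(=O)O)c1-c1cccc(Cl)c1C` gives 5100 nM;
compound 2 `Cc1c(-c2cc(Cl)cc(Cl)c2)c(C(=O)O)nn1-c1nc(-c2cc(Cl)ccc2F)c(SC(C)C)s1` gives 4800 nM.

Compound 1 carries the larger of the two numbers, yet its gap to compound 2 lies within the scatter, so the two cannot be told apart on this assay. Compound 3 `Cc1nn(-c2nc(-c3ccc(Cl)c(Cl)c3)c(SC(C)C)s2)c(C(=O)O)c1-c1ccccc1Cl` has not been measured. It differs from compound 1 in one place: 2-chlorophenyl in place of 3-chloro-2-methylphenyl on an aromatic carbon. Among the compounds with values here, no measured pair shows this change. Compound 3 is expected to give 7000 nM in this assay, with a range from 3000 nM to 17000 nM, the step of a 1.4-fold higher number from compound 1 to compound 3 (0.14 log units; within the scatter) expected to be small and not clearly beyond the scatter.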

Compound 3, half-maximal effective concentration: 13100 nM
For compound 3 the middle estimate is 1.9-fold (0.27 log units) below the measured one; low and high end bracket the measured number.
By their numbers in this assay, from the lowest: compounds 2 and 1 (each within the scatter of the next); then compound 3.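

In this assay, 2-chlorophenyl in place of 3-chloro-2-methylphenyl on this aromatic carbon gives a 2.6-fold higher number from compound 1 to compound 3 (0.41 log units; beyond the scatter), a modest step. Within the data shown here, it is the first single-place change in the set, and it shows that the read-out responds to the substitution of this phenyl ring. No measured evidence accounts for the step.

The change removes the methyl and also alters where the chlorine stands, and the compounds shown do not separate these two differences. From the compounds shown here alone, how 2-methylphenyl, or a phenyl ring carrying an amine, would read here remains open.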